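Replacing the acetyl of compound 2 with dimethylcarbamoyl

A few compounds are considered here, and "the series" means these few. Any claim that something is new, unique, unknown or untested is made for them only; others in the source may bear on it.

- compound 1 `CC(=O)NCC#CCn1ccnc1` gives > 100 mg/kg as a limit of the assay
- compound 2 `CC(=O)N(C)CC#CCn1ccnc1` gives 1.4 mg/kg as a number
- compound 3 `CC(=O)N(C)CC#CCn1cncc1C` gives 45 mg/kg as a number

Going by the values given here, all three values come from a functional assay on the whole organism for agonist activity, with Mus musculus as the target (a lower number here means that less compound is needed, a higher number that more compound is needed for the effect), and the one for compound 1 is a limit, not a number. Compound 2 at 1.4 mg/kg holds the lowest of the two true numbers, and compound 3 stands nearest to it.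

Compound 4 `CN(C)C(=O)N(C)CC#CCn1ccnc1` is still unmeasured and differs from compound 2 by dimethylamino in place of methyl on a carbonyl carbon in one place, dimethylamino in place of methyl on a carbonyl carbon. Among the compounds with values here, no measured step touches that carbonyl carbon. The nearest guides are an at least 71-fold lower number from compound 1 to compound 2 (1.85 log units; beyond the scatter) with methyl in place of hydrogen on an amide-type nitrogen, and a 32-fold higher number from compound 2 to compound 3 (1.51 log units; beyond the scatter) with methyl in place of hydrogen on an aromatic carbon. Both are large and they run in opposite directions, so among these three compounds small changes count for much.

Starting from compound 2 at 1.4 mg/kg as the lowest number, a higher number is expected in this assay for compound 4. The expected change is a 7.1-fold higher number from compound 2 to compound 4 (0.85 log units; beyond the scatter) and it remains uncertain in size. For compound 4 the estimated value is 10 mg/kg with an expected range from 2 mg/kg to 70 mg/kg in this estimate.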

Compound 4, dose for half-maximal effect: 25.4 mg/kg
Estimate against measurement, compound 4: 2.5-fold (0.40 log units) below; low and high end bracket the measured number.
By their numbers in this assay, from the lowest: compound 2; then compounds 4 and 3 (each within the scatter of the next). At a limit, above all of these: compound 1.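

Going by these compounds alone, the carbonyl carbon, which no earlier step touched, proves as sensitive as the other places changed: in this assay, going from acetyl to dimethylcarbamoyl gives an 18-fold higher number from compound 2 to compound 4 (1.26 log units; beyond the scatter). The amide-type end of the molecule therefore responds on its carbonyl side as well as on its nitrogen, where the methyl step gave an at least 71-fold lower number from compound 1 to compound 2 (1.85 log units; beyond the scatter), and in opposite directions. Compound 1 alone stands at a limit of the assay, not a number: the limit of > 100 mg/kg in this assay, at which 1 of the 4 values shown sits.

The compounds shown leave open whether the higher number belongs to the added nitrogen or to the added carbons, a question that an ethyl, a methoxy or a methylamino group on that carbonyl carbon could address. They also leave open how dimethylcarbamoyl behaves together with the added methyl of compound 3.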